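A Phenyl Swap on the Way to Compound 3

The compounds below may be only part of what the source reports. "The series", "measured", "known", "first", "only" and "open" are said of these compounds alone.

compound 1 `NC(=O)c1cc(Cl)ccc1NC(=O)/C=C/c1cccc(Br)c1`: 27%
compound 2 `NC(=O)c1cc(Br)ccc1NC(=O)/C=C/c1ccccc1Cl`: 59%

Both values come from a functional assay on K562 cells (Homo sapiens) for antiproliferative activity, read by trypan blue exclusion, with a stated time of 48 h, tested at 10 uM; a higher number here means more inhibition of growth at the concentration tested, a lower number less inhibition of growth. Of these two compounds, compound 2 stands higher at 59%, and the gap down to compound 1 lies beyond the usual scatter. The two compounds differ in more than one place, so no single structural change has yet been measured on its own.

The next compound to be tested is compound 3 `Cc1ccc(/C=C/C(=O)Nc2ccc(Br)cc2C(N)=O)cc1`, which differs from compound 2 in one place: 4-methylphenyl in place of 2-chlorophenyl on a double-bonded chain carbon bound to a double-bonded chain carbon. In words, 4-methylphenyl stands in place of 2-chlorophenyl on a double-bonded chain carbon bound to a double-bonded chain carbon.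

Within the data shown here, with no measured step to guide the expectation, only the range of the existing values offers a reference, and compound 1 at 27% shows that a lower reading is possible in this small set. A moderate fall is therefore expected, estimated as a number 14 percentage points lower from compound 2 to compound 3 (beyond the scatter). In this assay, the estimate for compound 3 is 45%, with an expected range from 22% to 68%.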

Compound 3, percent growth inhibition at one concentration: 45.9%
Compound 3: the middle estimate sits 0.9 percentage points below what was measured; measured number inside the range.
By their numbers in this assay, from the lowest: compound 1; then compound 3; then compound 2.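

Among these compounds, for the first time, a single change at this position is measured on its own: with the rest of the molecule held the same, putting 4-methylphenyl in place of 2-chlorophenyl on a double-bonded chain carbon bound to a double-bonded chain carbon gives a number 13.1 percentage points lower from compound 2 to compound 3 (beyond the scatter) in this assay. The two groups have the same number of heavy atoms and the same aromatic ring of carbon only, and neither has a hydrogen-bond donor, a hydrogen-bond acceptor or a net charge, so this modest step appears between groups that those computed counts do not tell apart. No measurement shown here accounts for the step.

The swap replaces chlorine with methyl and also changes the numbered ring position of the substituent, so the compounds shown leave open which of the two goes with the lower reading, a question that 2-methylphenyl and 4-chlorophenyl at this position could separate. Also open, as far as these compounds go, is how this position would respond to an unsubstituted phenyl group or to a phenyl group carrying an amine or a carboxylic acid.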